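The source may hold more compounds than are shown below. What is called first, only, known or untested is meant among the compounds shown, and "the series" means these compounds.

Measured so far in an assay on HEK293 cells for displacement of a labelled ligand from Melanocortin receptor 4 (Homo sapiens); a higher number here means a weaker inhibitor, a lower number a stronger inhibitor:
compound 1 `CC(C)C[C@H](N)c1cc(C(F)(F)F)ccc1N1CCN(C(=O)C(C)Cc2ccc(Cl)cc2O)CC1` gives 36 nM
compound 2 `CC(C)C[C@H](N)c1cc(C(F)(F)F)ccc1N1CCN(C(=O)COc2ccc(O)cc2)CC1` gives 4600 nM
compound 3 `CC(C)C[C@H](N)c1cc(C(F)(F)F)ccc1N1CCN(C(=O)COc2ccc([N+](=O)[O-])cc2)CC1` gives 3100 nM

Compound 3 stands second highest of the three numbers in this assay; its nearest neighbour is compound 2, with a 1.5-fold lower number from compound 2 to compound 3 (0.17 log units; within the scatter), and its furthest is compound 1, with an 86-fold higher number from compound 1 to compound 3 (1.94 log units; beyond the scatter). Compound 4 `CC(C)C[C@H](N)c1cc(C(F)(F)F)ccc1N1CCN(C(=O)COc2cccc3ccccc23)CC1` differs from compound 3 by naphthalen-1-yl in place of 4-nitrophenyl on an oxygen on a saturated carbon. Among the measured compounds shown here, no measured step covers this change directly. For the measured compounds named here, the only step that alters the aryl group on the ether oxygen is a 1.5-fold lower number from compound 2 to compound 3 (0.17 log units; within the scatter), which stayed within the scatter. The two large steps, a 130-fold higher number from compound 1 to compound 2 (2.11 log units; beyond the scatter) and an 86-fold higher number from compound 1 to compound 3 (1.94 log units; beyond the scatter), concern the exchange of the whole acyl side chain and do not bear on a change kept within the aryloxymethyl series. With the aryloxymethyl link retained, compound 4 is expected to remain in the weak range of compound 2 and compound 3 in this assay. For compound 4 the expected step is a 1.2-fold lower number from compound 3 to compound 4 (0.09 log units; within the scatter), within the scatter. Compound 4 is therefore estimated at 2500 nM in this assay, within 700 nM to 9000 nM.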

Compound 4, inhibition constant: 2600 nM
The estimate for compound 4 lay 1.0-fold (0.02 log units) below the measured number, within the range that was stated.
By their numbers in this assay, from the lowest: compound 1; then compounds 4, 3 and 2 (each within the scatter of the next).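

In this assay, naphthalen-1-yl in place of 4-nitrophenyl on the oxygen gives a 1.2-fold lower number from compound 3 to compound 4 (0.08 log units; within the scatter), and in place of 4-hydroxyphenyl it gives a 1.8-fold lower number from compound 2 to compound 4 (0.25 log units; within the scatter), so this position accepts two six-membered aromatic rings as readily as one, even with the hydrogen-bond acceptors of the nitro group gone. The gap to the acyl side chain of compound 1 remains with this third aryl group, at a 72-fold higher number from compound 1 to compound 4 (1.86 log units; beyond the scatter), and none of the three aryl groups closes it. No data on hand offer a reason for either finding.

Which part of the 1-(4-chloro-2-hydroxybenzyl)ethyl chain carries the gap remains open. Also open, from the compounds shown here alone, is whether a carboxylic acid or an amine on the aryl ring, or a longer chain before the ether oxygen, would move the number out of this range.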